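Three Dihydropyrimidinones Against an Adenosine Receptor, and a Fourth

A few compounds are considered here, and "the series" means these few. Any claim that something is new, unique, unknown or untested is made for them only; others in the source may bear on it.

Three compounds sharing one core have been examined in an assay on membranes from HeLa cells for displacement of a labelled ligand from adenosine receptor A3 (Homo sapiens), read by scintillation counting, with a stated time of 180 min, tested at 1 uM; on this read-out lower numbers stand for less inhibition and higher numbers for more inhibition at the one concentration tested (going by the name of the read-out). Compound 1 `CC1=C(C(=O)OCc2ccccc2)C(c2ccsc2)NC(=O)N1` gives 25% in this assay. Compound 2 `CC1=C(C(=O)OC(C)(C)C)C(c2ccoc2)NC(=S)N1` gives 19% in this assay. Compound 3 `COC(=O)C1=C(C)N(C)C(=O)NC1c1ccco1` gives 9% in this assay, the lowest of the three numbers. The gap between compound 3 and compound 2 lies within the usual scatter of such measurements, so the two cannot be ranked against each other; the gap between compound 3 and compound 1 lies beyond the scatter.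

The next compound, compound 4 `CC1=C(C(=O)OC(C)(C)C)C(c2ccco2)NC(=O)N1C`, remains to be measured in this assay. It differs from compound 3 in one place only: tert-butyl in place of methyl on an oxygen next to a carbonyl group. Among the compounds with values here, no measured pair differs in just this way, so the size of the step cannot be read from the numbers at hand. Within the data shown here, compound 2 also carries a tert-butyl group on an oxygen next to a carbonyl group, but it differs from compound 3 in several other places as well, so its value shows only that such a compound can sit near compound 3 within the scatter.

The step from compound 3 to compound 4 is therefore expected to be small, a number 6 percentage points higher from compound 3 to compound 4 (within the scatter), most likely not beyond the scatter in either direction. For compound 4 the estimate in this assay is 15%, with a range from 3% to 30%.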

Compound 4, a percentage reported as inhibition, at one concentration (the size of the read-out at that concentration, not a potency): 54%
The estimate for compound 4 lay 39 percentage points below the measured number; the whole stated range lies below it.
By their numbers in this assay, from the lowest: compounds 3, 2 and 1 (each within the scatter of the next, the first and the last beyond it); then compound 4.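

In this assay, the change from methyl to tert-butyl on an oxygen next to a carbonyl group brings a number 45 percentage points higher from compound 3 to compound 4 (beyond the scatter), a large step. Within the data shown here, this shows that the position is not a passive one: altering only this small group, from one carbon to four with the rest of the molecule unchanged, is enough to move the read-out well beyond ordinary scatter, something the earlier compounds could not show, as no two of them differed in just one place. Nothing at hand accounts for the size of this step, so the numbers record the effect without explaining it.

Among these compounds, the single pair gives only two points at this position, so it remains open how the number would change with an ethyl or isopropyl group in between, or with a free carboxylic acid in place of the methoxycarbonyl group. Going by these compounds, it also remains open whether the same swap from methoxycarbonyl to tert-butoxycarbonyl would bring a step of similar size on a compound that differs elsewhere on the shared core.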